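Fluoro Traded for Trifluoromethoxy on a Shared Core

A few compounds are considered here, and "the series" means these few. Any claim that something is new, unique, unknown or untested is made for them only; others in the source may bear on it.

Measured compounds:
Compound 1 `Oc1ccc(-c2cc(-c3ccc(F)cc3)cc(-c3ccccc3O)n2)cc1` in a functional assay on HCT-15 cells (Homo sapiens) for inhibition (a lower number here means a stronger inhibitor, a higher number a weaker inhibitor), reports only a limit, > 50000 nM.
Compound 2 `Oc1ccc(-c2cc(-c3ccccc3F)cc(-c3ccc(O)cc3)n2)cc1` gives 8180 nM.
Compound 3 `Oc1ccc(-c2cc(-c3ccc(F)cc3)cc(-c3ccc(O)cc3)n2)cc1` gives 4970 nM.

Compound 3 and compound 2 sit within the usual scatter of each other, a 1.6-fold lower number from compound 2 to compound 3 (0.22 log units; within the scatter). Within the data shown here, the one clear step, an at least 10-fold lower number from compound 1 to compound 3 (1.00 log units; beyond the scatter), moves the hydroxy group rather than the fluoro, and compound 1 sits at the limit of > 50000 nM in this assay, at which 1 of the 3 values shown sits. Compound 4 `Oc1ccc(-c2cc(-c3ccc(OC(F)(F)F)cc3)cc(-c3ccc(O)cc3)n2)cc1` differs from compound 3 by trifluoromethoxy in place of fluoro on an aromatic carbon. Among the measured compounds shown here, no measured step exchanges the group at this place; the only nearby step moved the fluoro and stayed within scatter. The step of a 1.0-fold higher number from compound 3 to compound 4 (0.00 log units; within the scatter) is therefore expected to stay within scatter. Compound 4 is estimated at 5000 nM, with a range from 1500 nM to 16000 nM.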

Compound 4, half-maximal inhibitory concentration: 13900 nM
For compound 4 the middle estimate is 2.8-fold (0.44 log units) below the measured one; low and high end bracket the measured number.
By their numbers in this assay, from the lowest: compounds 3, 2 and 4 (each within the scatter of the next, the first and the last beyond it). At a limit, above all of these: compound 1.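

Among these compounds, this is the first exchange of the group at this place, on an aromatic carbon para to a large group, and in this assay it is not silent: trifluoromethoxy in place of fluoro gives a 2.8-fold higher number from compound 3 to compound 4 (0.45 log units; beyond the scatter). The position therefore responds to a change of group, although the step is modest. The compounds shown offer no measurement that explains this step. Going by these compounds, it remains open how an amine, a carboxylic acid or a longer chain such as butoxy would fare at this place.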